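Swapping cyclohexyl for a sulfone ring on a piperidine amide

The source may hold more compounds than are shown below. What is called first, only, known or untested is meant among the compounds shown, and "the series" means these compounds.

In an ADME assay (liver) for metabolic stability, with Liver microsome (Homo sapiens) as the target, read by LC-MS, using microsomes and NADPH, tested at 1 uM (a higher number here means that the compound lasts longer, a lower number that the compound disappears faster), two compounds sharing one core have been measured. Compound 1 `CC(C)(C)c1cc(NC(=O)[C@@H]2CCCCN2C(=O)c2ccc(Cl)cc2)no1` gives 1.25 h. Compound 2 `CC(C)(C)c1cc(NC(=O)[C@@H]2CCCCN2C(=O)C2CCCCC2)no1`, which carries cyclohexyl in place of 4-chlorophenyl on a carbonyl carbon, gives 0.483 h, the lowest of the two numbers; the step of a 2.6-fold lower number from compound 1 to compound 2 (0.41 log units; beyond the scatter) lies beyond the scatter, so compound 2 stands clearly below compound 1.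

Compound 3 `CC(C)(C)c1cc(NC(=O)[C@@H]2CCCCN2C(=O)C2CCS(=O)(=O)CC2)no1` has not been measured. It differs from compound 2 as follows: 1,1-dioxothian-4-yl in place of cyclohexyl on a carbonyl carbon. Among the measured steps, only a 2.6-fold lower number from compound 1 to compound 2 (0.41 log units; beyond the scatter) touches the same carbonyl carbon, and it exchanged one carbon ring for another rather than introducing a ring with a hetero atom. For the measured compounds named here, no measured pair shows what a 1,1-dioxothian-4-yl does at this position, so the data give no direct guide to the direction.

With that in mind, the half-life of compound 3 in this assay is expected to be around 0.9 h, with a plausible range from 0.4 h to 2 h. This expectation corresponds to a step of a 1.9-fold higher number from compound 2 to compound 3 (0.27 log units; within the scatter), which is estimated as modest at most.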

Compound 3, half-life: > 2 h
Compound 3: only a limit was reported; the forecaster's own chance of this, stated with the estimate: 5%; middle value at least 2.2-fold (0.34 log units) away from the limit.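

In this assay, this position on a carbonyl carbon proves sensitive to a hetero atom in the ring, something the two earlier groups, neither of which carries one, could not show: 1,1-dioxothian-4-yl in place of cyclohexyl gives an at least 4.1-fold higher number from compound 2 to compound 3 (0.61 log units; beyond the scatter). The earlier step, a 2.6-fold lower number from compound 1 to compound 2 (0.41 log units; beyond the scatter), had left the non-aromatic ring as the poorer of the two groups, but compound 3 shows that a short half-life does not come with a non-aromatic ring as such. Against 4-chlorophenyl, the new group gives an at least 1.6-fold higher number from compound 1 to compound 3 (0.20 log units; that floor lies within the scatter), so this floor alone supports no order between those two compounds.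

Compound 3 reads > 2 h, which is a limit and not a number, so how far its half-life extends stays open: the limit of > 2 h in this assay, at which 1 of the 3 values shown sits. The compounds shown also leave open whether the gain needs the two oxygens on the sulfur or would appear with any hetero atom in the ring, as a thian-4-yl with plain sulfur, an oxan-4-yl or a piperidin-4-yl on the same carbonyl carbon would tell.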